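This account rests on a few compounds, and the source may have more. Where it says the series, first, only, none or still open, it means among the compounds named here.

Values in a functional assay on MDA-MB-231 cells (Homo sapiens) for antiproliferative activity, read by MTT assay, with a stated time of 72 h; on this read-out lower numbers stand for stronger inhibition and higher numbers for weaker inhibition:
compound 1 `CCNC(=O)CCc1cccc2c1B(O)OC2`: > 100000 nM, a limit
compound 2 `CC(C)(C)NC(=O)CCc1cccc2c1B(O)OC2`: > 100000 nM, a limit
compound 3 `O=C(CCc1cccc2c1B(O)OC2)Nc1ccc(I)cc1`: 33000 nM

Among the measured compounds shown here, compound 3 is the only compound with an actual number, and the other two stand at the limit of > 100000 nM in this assay, at which 2 of the 3 values shown sit. Compound 4 `CCOC(=O)c1ccc(NC(=O)CCc2cccc3c2B(O)OC3)cc1` differs from compound 3 in one place: ethoxycarbonyl in place of iodo on an aromatic carbon, (ethoxycarbonyl in place of iodo on an aromatic carbon).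

For the measured compounds named here, two measured steps bear on this only indirectly. Putting 4-iodophenyl in place of ethyl on the amide-type nitrogen gave an at least 3.0-fold lower number from compound 1 to compound 3 (0.48 log units; beyond the scatter), and putting it in place of tert-butyl gave an at least 3.0-fold lower number from compound 2 to compound 3 (0.48 log units; beyond the scatter). Both are at least modest, but neither varies the group now being exchanged, so the series gives no measured size for this change. Compound 4 keeps the aromatic ring on that nitrogen, so the anchor is compound 3 at 33000 nM.

No step beyond the scatter is expected, and the estimated step is a 1.2-fold higher number from compound 3 to compound 4 (0.08 log units; within the scatter). For compound 4 the estimate is 40000 nM, with an expected range of 13000 nM to 100000 nM.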

Compound 4, half-maximal inhibitory concentration: > 100000 nM
Compound 4 gave a limit, no number (the forecaster's own chance of this, stated with the estimate: 30%); middle value at least 2.5-fold (0.39 log units) from the limit.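

Among the compounds shown here, on the aromatic carbon para to a large group, ethoxycarbonyl in place of iodo gave an at least 3.0-fold higher number from compound 3 to compound 4 (0.48 log units; beyond the scatter) in this assay, the first measured change at this position. Compound 4 keeps the aromatic ring on the amide-type nitrogen and still gives > 100000 nM, a limit, so that ring alone does not secure a measurable value, and the group on this carbon also counts. The series now holds a single number against three limits: the limit of > 100000 nM in this assay, at which 3 of the 4 values shown sit.

On these data alone, whether chloro, methyl, a carboxylic acid or an amine on this carbon would give a number remains open. Also open, as far as these compounds go, is whether the lower number seen with 4-iodophenyl carries over to a pyridine ring on the amide-type nitrogen.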